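The source may hold more compounds than are shown below. What is called first, only, known or untested is meant among the compounds shown, and "the series" means these compounds.

Of the compounds shown here, three sharing one core have been measured so far in a functional assay on MCF7 cells (Homo sapiens) for cytotoxicity, read by MTT assay, with a stated time of 96 h; on this read-out lower numbers stand for stronger inhibition and higher numbers for weaker inhibition. Compound 1 (`COc1cc(C(=O)c2cn(-c3ccccc3)cc2-c2ccccc2Cl)cc(OC)c1OC`) gives 76 nM there, compound 2 (`COc1cc(C(=O)c2cn(-c3ccccc3)cc2-c2ccccc2Br)cc(OC)c1OC`) gives 190 nM there, and compound 3 (`COc1ccc(-c2cn(-c3ccccc3)cc2C(=O)c2cc(OC)c(OC)c(OC)c2)cc1`) gives 70 nM there. The place of compound 3 follows from two steps: a 1.1-fold lower number from compound 1 to compound 3 (0.04 log units; within the scatter) and a 2.7-fold lower number from compound 2 to compound 3 (0.43 log units; beyond the scatter) together leave it level with the one and lower than the other.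

Compound 4 (`COc1cc(C(=O)c2cn(-c3ccccc3)cc2/C=C/c2ccccc2)cc(OC)c1OC`) has yet to be measured, and its change from compound 3 reads in full 2-phenylethenyl in place of 4-methoxyphenyl on an aromatic carbon as the difference. In words, 2-phenylethenyl stands in place of 4-methoxyphenyl.

The nearest evidence is the exchange of groups at this same place, where a 1.1-fold lower number from compound 1 to compound 3 (0.04 log units; within the scatter) stays within the scatter and a 2.7-fold lower number from compound 2 to compound 3 (0.43 log units; beyond the scatter) is modest. The halogen exchange, a 2.5-fold higher number from compound 1 to compound 2 (0.40 log units; beyond the scatter) in size, is modest too. For the measured compounds named here, no measured compound carries a double bond outside aromatic rings, so the data reach this change only indirectly.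

A modest move is therefore the reasonable expectation, and the estimate is a 2.1-fold higher number from compound 3 to compound 4 (0.33 log units; beyond the scatter) as a shift towards a higher number. For compound 4 the estimated value is 150 nM and the expected range runs from 40 nM up to 550 nM in this assay once it is tested.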

Compound 4, half-maximal inhibitory concentration: 2200 nM
The estimate for compound 4 lay 15-fold (1.17 log units) below the measured number; the whole stated range lies below it.
By their numbers in this assay, from the lowest: compounds 3 and 1 (each within the scatter of the next); then compound 2; then compound 4.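

At this position, the aromatic groups measured earlier moved the number in this assay only modestly or not beyond the scatter, but 2-phenylethenyl, the group that brings a double bond outside aromatic rings, proved much less well tolerated. Its entry in place of 4-methoxyphenyl is a large step (a 31-fold higher number from compound 3 to compound 4 (1.50 log units; beyond the scatter)), and the exchanges for the two halogenated phenyl groups are large as well (a 29-fold higher number from compound 1 to compound 4 (1.46 log units; beyond the scatter); a 12-fold higher number from compound 2 to compound 4 (1.06 log units; beyond the scatter)), so the loss appears against all three measured groups at this carbon, including the least favourable of them. Nothing measured here accounts for this loss.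

The compounds shown leave open whether the loss is tied to the double bond itself, a question that a compound with 2-phenylethyl or phenylethynyl at this carbon would address. They also leave open whether a methoxy group or a chlorine on the phenyl ring of 2-phenylethenyl would recover any of the lost activity, and whether the geometric isomer of the double bond would behave in the same way.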